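Pyridin-2-yl in Place of Cyanomethyl on the Amine

A few compounds are considered here, and "the series" means these few. Any claim that something is new, unique, unknown or untested is made for them only; others in the source may bear on it.

Measured so far:
compound 1, `N#CCN(Cc1ccccc1)Cc1ccc2ccccc2c1`: 0%
compound 2, `N#CCN(Cc1ccc(I)cc1)Cc1ccc2ccccc2c1`: 0%

In an assay on HEK293 cells for binding affinity to Substance-K receptor (Rattus norvegicus), read by FRET, tested at 10 uM (on this read-out higher numbers stand for more inhibition at the one concentration tested (going by the name of the read-out) and lower numbers for less inhibition), compound 1 gives 0%, level with compound 2 at the digits shown. Going by the values given here, the one measured step, no change at the digits printed from compound 1 to compound 2 (within the scatter), concerns an aromatic substituent and stays within the scatter. Compound 3 `c1ccc(CN(Cc2ccc3ccccc3c2)c2ccccn2)cc1` carries pyridin-2-yl in place of cyanomethyl on an amine nitrogen. Among the compounds with values here, no measured step touches the amine nitrogen, so the single step gives no direction for this change. Because compound 1 gives 0% and the read-out cannot sensibly fall much further, compound 3 is expected near 0%, with a range from -10% to 15%. The expected step is no change at the digits printed from compound 1 to compound 3 (within the scatter), none beyond the scatter.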

Compound 3, a percentage reported as inhibition, at one concentration (the size of the read-out at that concentration, not a potency): 17%
Compound 3: middle estimate off by 17 percentage points, on the low side; the measured number lies above the stated range.
By their numbers in this assay, from the lowest: compounds 1 and 2 (each within the scatter of the next); then compound 3.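

In this assay, pyridin-2-yl in place of cyanomethyl on the amine nitrogen gives a number 17 percentage points higher from compound 1 to compound 3 (beyond the scatter), the only step shown that lies beyond the scatter. The amine nitrogen is thus a place where this read-out can respond, unlike the iodo change on an aromatic carbon, which gave no change at the digits printed from compound 1 to compound 2 (within the scatter). Nothing available explains why the number rises with this change. The compounds shown leave open whether the ring nitrogen of pyridin-2-yl matters, a question that phenyl on the amine nitrogen would address. They also leave open whether iodo would have any effect on compound 3.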